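This account rests on a few compounds, and the source may have more. Where it says the series, first, only, none or still open, it means among the compounds named here.

Compound 1: `O=c1cc(/C=N\c2ccc(O)cc2)c2ccc(OCc3ccccc3)cc2o1` gives 233000 nM in a functional assay, read by spectrophotometry, with a stated time of 1 h; on this read-out lower numbers stand for stronger inhibition and higher numbers for weaker inhibition.
Compound 2: `O=c1cc(/C=N\O)c2ccc(OCc3ccccc3)cc2o1` gives > 2000000 nM in this assay, which is a limit of the assay and not a number.

Compound 2 therefore stands at the edge of what can be reported: it sits at the limit of > 2000000 nM in this assay, at which 1 of the 2 values shown sits, so only a bound is known for it, and the step of an at least 8.5-fold higher number from compound 1 to compound 2 (0.93 log units; beyond the scatter) is itself only a bound. Compound 3, `O=c1cc(-c2nc3ccccc3[nH]2)c2ccc(OCc3ccccc3)cc2o1`, has not been measured. It differs from compound 2 by a group of 9 heavy atoms (7 carbon, 2 nitrogen; one five-membered aromatic ring with 2 hetero atoms, one six-membered aromatic ring of carbon only) in place of a group of 3 heavy atoms (1 carbon, 1 nitrogen, 1 oxygen; no ring), on an aromatic carbon. For the measured compounds named here, no measured step matches this change. Going by the values given here, the single measured step bears on it only indirectly: compound 1 carries a 4-hydroxyphenyl on the double-bonded nitrogen, and an at least 8.5-fold higher number from compound 1 to compound 2 (0.93 log units; beyond the scatter) shows that trading that ring for a hydroxy weakened inhibition beyond the scatter. The change to compound 3 again places a larger aromatic group on the same carbon, though of a different kind and without the double-bonded nitrogen. On that slender guide, a step back from the limit toward a measurable number is expected for compound 3, an at least 8.0-fold lower number from compound 2 to compound 3 (0.90 log units; beyond the scatter). In this assay compound 3 is estimated at 250000 nM, between 50000 nM and 1500000 nM, with a real chance that only a limit is returned.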

Compound 3, half-maximal inhibitory concentration: "not active" (no number reported)
The entry for compound 3 holds no number; no gap can be computed for the estimate.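

In this assay, for the compounds shown here, compound 3 is reported as "not active", without a number, so no step from compound 2 to compound 3 can be read. The compounds shown leave open whether inhibition by compound 3, with its 1H-benzimidazol-2-yl group, differs at all from that by compound 2.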